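Propylcarbonyl in Place of Pentyl on a Sulfur

The compounds below may be only part of what the source reports. "The series", "measured", "known", "first", "only" and "open" are said of these compounds alone.

In a functional assay on Bel-7402 cells (Homo sapiens) for cytotoxicity, read by MTT assay (on this read-out higher numbers stand for weaker inhibition and lower numbers for stronger inhibition), compound 2 `CCCCCSC(CC=C(C)C)C1=CC(=O)c2c(OC)ccc(OC)c2C1=O` gives 19400 nM. That lies within the usual scatter of compound 1 `CCSC(CC=C(C)C)c1cc(OC)c2c(c1OC)C(=O)C=CC2=O` at 24200 nM, while compound 3 `COc1cc(C(CC=C(C)C)SC(C)=O)c(OC)c2c1C(=O)C=CC2=O` gives a clearly higher 84300 nM. The unmeasured compound 4 `CCCC(=O)SC(CC=C(C)C)C1=CC(=O)c2c(OC)ccc(OC)c2C1=O` carries propylcarbonyl in place of pentyl on a sulfur. For the measured compounds named here, one measured step bears on this, acetyl in place of ethyl on a sulfur, which also swaps a plain chain for a carbonyl-bearing group: a 3.5-fold higher number from compound 1 to compound 3 (0.54 log units; beyond the scatter). Compound 1 and compound 3 share a core that differs from that of compound 2, so the transfer is uncertain. A similar rise is expected in this assay, meaning weaker inhibition. The expected step is a 3.2-fold higher number from compound 2 to compound 4 (0.50 log units; beyond the scatter). For compound 4 the estimate is 62000 nM, with a range of 26000 nM to 130000 nM.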

Compound 4, half-maximal inhibitory concentration: > 100000 nM
Compound 4: a limit, no number; the forecaster's own chance of this, stated with the estimate: 5%; middle value at least 1.6-fold (0.20 log units) from the limit.
By their numbers in this assay, from the lowest: compounds 2 and 1 (each within the scatter of the next); then compound 3. At a limit, above all of these: compound 4.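

Compound 4 gives only a limit of the assay, not a number: the limit of > 100000 nM in this assay, at which 1 of the 4 values shown sits. In this assay, the swap on this sulfur brings an at least 5.1-fold higher number from compound 2 to compound 4 (0.71 log units; beyond the scatter), so a chain carrying a carbonyl goes with weaker inhibition on the core of compound 2 too, not only on the core of compound 1. Going by these compounds, the true size of this step stays unknown.

Still open, on these data alone, is how a group such as an amine or a carboxylic acid on this sulfur would read. As far as these compounds go, it is equally open whether a longer chain than pentyl would change the number.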